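This account rests on a few compounds, and the source may have more. Where it says the series, first, only, none or still open, it means among the compounds named here.

The measured compounds in this study:

compound 1, `CCc1cc(C(C)=O)c(O)cc1OCCCCC(C)(C)C#N`, with 79% in an assay on isolated protein for inhibition of leukotriene B4 receptor 1 (Homo sapiens), tested at 10 uM; on this read-out lower numbers stand for less inhibition and higher numbers for more inhibition at the one concentration tested (going by the name of the read-out);
compound 2, `CCc1cc(C(C)=O)c(O)cc1OCCCCCC(C)(C)C#N`, with 85%;
compound 3, `CCc1cc(C(C)=O)c(O)cc1OCCCC(C)(C)c1nnn[nH]1`, with 100%.

Compound 3 stands highest of the three numbers. Its nearest neighbour is compound 2, with a number 15 percentage points higher from compound 2 to compound 3 (beyond the scatter), and its furthest is compound 1, with a number 21 percentage points higher from compound 1 to compound 3 (beyond the scatter). Between the two nitrile compounds the step is a number 6 percentage points higher from compound 1 to compound 2 (within the scatter).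

Compound 4, `CCc1cc(C(C)=O)c(O)cc1OCCCCCC[S+](C)[O-]`, is not yet measured. It differs from compound 3 as follows: a group of 6 heavy atoms (4 carbon, 1 oxygen, 1 sulfur; no ring) in place of a group of 8 heavy atoms (4 carbon, 4 nitrogen; one five-membered aromatic ring with 4 hetero atoms), on a saturated chain carbon, three bonds along the chain from an oxygen on an aromatic ring. The group that leaves carries the five-membered aromatic ring with four hetero atoms and the one hydrogen-bond donor; the group that enters has no ring and no donor.

Among the compounds with values here, the steps that bear on this change are those from the nitrile compounds to compound 3, each beyond the scatter and each modest. Both went upward on gaining the tetrazolyl group; compound 4 gives it up for a group that is also without a ring, as the nitrile groups are. The account therefore expects a downward step, a number 24 percentage points lower from compound 3 to compound 4 (beyond the scatter), of a size similar to those two steps. Compound 4 is estimated at 76%, within a range from 52% to 94%.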

Compound 4, a percentage reported as inhibition, at one concentration (the size of the read-out at that concentration, not a potency): 92%
Beside the measured number, compound 4's estimate is 16 percentage points below it; the range from low to high includes it.
By their numbers in this assay, from the lowest: compounds 1, 2, 4 and 3 (each within the scatter of the next, the first and the last beyond it).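

In this assay, the tetrazolyl group of compound 3 gives way at this place to an open-chain group holding sulfur and oxygen, with no ring and no hydrogen-bond donor, and the result is a number 8 percentage points lower from compound 3 to compound 4 (within the scatter). Against the nitrile compounds, the same comparison gives a number 7 percentage points higher from compound 2 to compound 4 (within the scatter) and a number 13 percentage points higher from compound 1 to compound 4 (beyond the scatter), so the earlier upward steps to compound 3 do not establish that the ring or the donor is required for a high number here. Nothing at hand accounts for this result.

From the compounds shown here alone, a percentage at one concentration is not a potency, so how compound 3 and compound 4 compare in potency remains open. Going by these compounds, it also remains open how a carboxylic acid or a sulfone at the end of the chain would read out.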